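Aryl swaps on the ring amine nitrogen of the shared core

The source may hold more compounds than are shown below. What is called first, only, known or untested is meant among the compounds shown, and "the series" means these compounds.

Compound 1 `COc1ccccc1N1CCN(Cn2nc(-c3ccc4c(c3)OCCO4)oc2=S)CC1`: > 50000 nM
Compound 2 `COc1ccc(N2CCN(Cn3nc(-c4ccc5c(c4)OCCO5)oc3=S)CC2)cc1`: > 50000 nM
Compound 3 `O=[N+]([O-])c1ccc(N2CCN(Cn3nc(-c4ccc5c(c4)OCCO5)oc3=S)CC2)cc1`: 31700 nM

In a functional assay on HeLa cells (Homo sapiens) for antiproliferative activity, read by MTT assay, with a stated time of 48 h (on this read-out lower numbers stand for stronger inhibition and higher numbers for weaker inhibition), compound 1 reaches only the limit > 50000 nM, not a number. Compound 2 likewise gives only the limit > 50000 nM in this assay. For the measured compounds named here, compound 3 gives 31700 nM in this assay, the one measured number; the limit of > 50000 nM in this assay, at which 2 of the 3 values shown sit, is where the other two stand. Compound 4 `S=c1oc(-c2ccc3c(c2)OCCO3)nn1CN1CCN(c2ccccn2)CC1` differs from compound 1 by pyridin-2-yl in place of 2-methoxyphenyl on an amine nitrogen in a ring. Going by the values given here, the steps that bear on it both swap the group on that ring nitrogen: a step that the two limits leave unreadable from compound 1 to compound 2 and an at least 1.5-fold lower number from compound 1 to compound 3 (0.19 log units; that floor lies within the scatter). Neither shows a readable change beyond the scatter, and compound 1 is known only as a limit. For compound 4 the estimate is therefore a value near the limit, 50000 nM (between 20000 nM and 120000 nM). The expected step is thus a number no higher from compound 1 to compound 4 (the limit leaves the size open), with a real chance that only a limit is reported again.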

Compound 4, half-maximal inhibitory concentration: 25100 nM
Compound 4: middle estimate off by 2.0-fold (0.30 log units), on the high side; measured number inside the range.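

Pyridin-2-yl on the ring nitrogen gives a measured number in this assay, so this position also accepts an aromatic ring with a hetero atom without leaving the assay range. The change gives an at least 1.9-fold lower number from compound 1 to compound 4 (0.29 log units; that floor lies within the scatter) and an at least 1.9-fold lower number from compound 2 to compound 4 (0.29 log units; that floor lies within the scatter), but both steps are only floors, because the starting values are limits: the limit of > 50000 nM in this assay, at which 2 of the 4 values shown sit.

Against the other measured compound, the change gives a 1.3-fold lower number from compound 3 to compound 4 (0.10 log units; within the scatter), so pyridin-2-yl and 4-nitrophenyl are not told apart. On these data alone, whether any group here moves the number beyond the scatter remains open. So does the effect of a pyrimidin-2-yl ring or a carboxylic acid on the phenyl ring.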